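Aryl variation on the five-membered ring of the nucleoside core

A few compounds are considered here, and "the series" means these few. Any claim that something is new, unique, unknown or untested is made for them only; others in the source may bear on it.

Measured so far in a functional assay on HCT-116 cells (Homo sapiens), read by MTT assay, with a stated time of 72 h; on this read-out lower numbers stand for stronger inhibition and higher numbers for weaker inhibition:
compound 1 `COc1ncnc2c1c(-c1ccoc1)cn2[C@@H]1O[C@H](CO)[C@@H](O)[C@H]1O`: 130 nM
compound 2 `COc1ncnc2c1c(-c1ccccc1)cn2[C@@H]1O[C@H](CO)[C@@H](O)[C@H]1O`: > 20000 nM
compound 3 `CNc1ncnc2c1c(-c1ccccc1)cn2[C@@H]1O[C@H](CO)[C@@H](O)[C@H]1O`: > 100000 nM

Going by the values given here, compound 1 is the only member with a number in this assay, where compound 1 gives 130 nM. For compound 2 the value in this assay is a limit, > 20000 nM, which is the limit of > 20000 nM in this assay, at which 1 of the 3 values shown sits. For compound 3 the value in this assay is likewise a limit, > 100000 nM, at the limit of > 100000 nM in this assay, at which 1 of the 3 values shown sits. Compound 2 therefore stands at a limit, with no number of its own to compare against compound 1 beyond the step of an at least 150-fold higher number from compound 1 to compound 2 (2.18 log units; beyond the scatter), which shows that phenyl in place of furan-3-yl is very costly here. The step that the two limits leave unreadable from compound 2 to compound 3 cannot be read, as both ends are limits.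

Compound 4 `COc1ncnc2c1c(-c1cc3ccccc3o1)cn2[C@@H]1O[C@H](CO)[C@@H](O)[C@H]1O` carries 1-benzofuran-2-yl in place of phenyl on an aromatic carbon. Among the compounds with values here, the only readable step that bears on it, an at least 150-fold higher number from compound 1 to compound 2 (2.18 log units; beyond the scatter), went from a furan to phenyl; the change to compound 4 brings a furan back, though as 1-benzofuran-2-yl rather than furan-3-yl, so a partial return toward the number of compound 1 is expected, with considerable uncertainty. The expected step is an at least 10-fold lower number from compound 2 to compound 4 (1.00 log units; beyond the scatter). Compound 4 is estimated at 2000 nM, within a range of 200 nM to 20000 nM.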

Compound 4, half-maximal inhibitory concentration: 14500 nM
Compound 4: the middle estimate sits 7.3-fold (0.86 log units) below what was measured; the range from low to high includes it.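

In this assay, the step of a 110-fold higher number from compound 1 to compound 4 (2.05 log units; beyond the scatter) shows that a furan ring within the group at this position does not by itself keep the potency of the furan-3-yl member. Against phenyl, the step of an at least 1.3-fold lower number from compound 2 to compound 4 (0.13 log units; that floor lies within the scatter) has a floor within the scatter, so no gain from 1-benzofuran-2-yl over phenyl can be stated. Compound 2 stands at a limit: the limit of > 20000 nM in this assay, at which 1 of the 4 values shown sits.

Since 1-benzofuran-2-yl differs from furan-3-yl both in the added six-membered ring and in the point of attachment, the compounds shown cannot separate these two changes, and furan-2-yl or thiophen-3-yl at this position would speak to that question. As far as these compounds go, it also remains open whether methylamino in place of methoxy is tolerated when furan-3-yl occupies this position, as methylamino appears here only with phenyl.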